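Compound 1 to compound 4: methyl to ethyl

A few compounds are considered here, and "the series" means these few. Any claim that something is new, unique, unknown or untested is made for them only; others in the source may bear on it.

Going by the values given here, in an ADME assay on MDCKII-LE cells (Canis lupus familiaris) for permeability (on this read-out higher numbers stand for higher permeability and lower numbers for lower permeability), the series has only two numbers so far. Compound 1 `Cc1cnc(NC(=O)c2cc(Oc3ccc(S(C)(=O)=O)cc3)c3cn(C)nc3c2)cn1` gives 20.4 10^-6 cm/s, and compound 2 `Cc1cnc(NC(=O)c2cc(Oc3ccc(S(=O)(=O)N(C)C)cc3)c3cn(C)nc3c2)cn1` gives 13.6 10^-6 cm/s. Among the compounds with values here, the step between them, a 1.5-fold lower number from compound 1 to compound 2 (0.18 log units; within the scatter), leaves compound 1 level with the only other measured member of the series. For compound 3 `CNS(=O)(=O)c1ccc(Oc2cc(C(=O)Nc3cnc(C)cn3)cc3nn(C)cc23)cc1` the result reads "not determined" (no result reported), so it adds nothing to the comparison.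

Compound 4 `CCn1cc2c(Oc3ccc(S(C)(=O)=O)cc3)cc(C(=O)Nc3cnc(C)cn3)cc2n1` differs from compound 1 in one place: methyl in place of hydrogen on a saturated chain carbon bound to an aromatic nitrogen. This is methyl in place of hydrogen on a saturated chain carbon bound to an aromatic nitrogen, which reads as methyl to ethyl when cut one bond further out.

Within the data shown here, no measured step covers this place. The nearest evidence is dimethylamino in place of methyl on a sulfonyl sulfur, a change elsewhere in the molecule, and that step stayed small at a 1.5-fold lower number from compound 1 to compound 2 (0.18 log units; within the scatter). It offers only weak support, and it gives no direction for the new change. No shift beyond the scatter is therefore expected in this assay. The expected step is a 1.1-fold lower number from compound 1 to compound 4 (0.03 log units; within the scatter). For compound 4 the estimated value is 19 10^-6 cm/s, with an expected range of 10 10^-6 cm/s to 34 10^-6 cm/s.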

Compound 4, apparent permeability: 13.4 10^-6 cm/s
For compound 4 the middle estimate is 1.4-fold (0.15 log units) above the measured one, within the range that was stated.
By their numbers in this assay, from the lowest: compounds 4, 2 and 1 (each within the scatter of the next).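

In this assay, going by these compounds alone, methyl in place of hydrogen on a saturated chain carbon bound to an aromatic nitrogen gives a 1.5-fold lower number from compound 1 to compound 4 (0.18 log units; within the scatter) and so provides the first reading at this position. Together with the step for dimethylamino in place of methyl on a sulfonyl sulfur (a 1.5-fold lower number from compound 1 to compound 2 (0.18 log units; within the scatter)), it means that changes at two separate places on the core of compound 1 have now been read, and neither step lies beyond the scatter; on this read-out, methyl to ethyl leaves compound 4 level with compound 1. No supporting data bear on the reason for this result.

As far as these compounds go, one added carbon is a small probe of this position, so it remains open whether a longer chain such as propyl, a branched chain such as isopropyl, or a chain ending in an amine or a carboxylic acid would also stay within the scatter. Also open, from the compounds shown here alone, is whether ethyl at this place and dimethylamino on the sulfonyl sulfur, each read so far only as a single change from compound 1, would stay within the scatter when carried together on one molecule.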